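The compounds below may be only part of what the source reports. "The series", "measured", "known", "first", "only" and "open" are said of these compounds alone.

Measured so far:
- compound 1 `Brc1ccc2ccn(CCN3CCC4CCCCN4CC3)c2c1`: 71%
- compound 2 `CN1CCCN(CCn2ccc3ccc(N)cc32)CC1`: 0%

Within the data shown here, in an assay on HEK293 cells for binding affinity to 5-hydroxytryptamine receptor 7 (Homo sapiens), read by radioligand binding, tested at 1 uM (on this read-out lower numbers stand for less inhibition and higher numbers for more inhibition at the one concentration tested (going by the name of the read-out)), compound 2 gives 0%, the lowest of the two numbers known, while compound 1 gives 71%, a gap beyond the scatter. Compound 3 `Cc1ccc2ccn(CCN3CCCN(C)CC3)c2c1` has not yet been measured. It differs from compound 2 by methyl in place of amino on an aromatic carbon. Among the measured compounds shown here, no measured pair shows this same change, so its size can only be guessed from compound 1 and compound 2. Some rise from compound 2 is expected, roughly a number 30 percentage points higher from compound 2 to compound 3 (beyond the scatter), with wide uncertainty. Compound 3 is expected to give about 30%, somewhere from 5% to 65%.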

Compound 3, a percentage reported as inhibition, at one concentration (the size of the read-out at that concentration, not a potency): 62%
For compound 3 the middle estimate is 32 percentage points below the measured one; the range from low to high includes it.
By their numbers in this assay, from the lowest: compound 2; then compounds 3 and 1 (each within the scatter of the next).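

In this assay, the group on this aromatic carbon, meta to a fused ring and para to a fused ring, matters on its own: methyl in place of amino gives a number 62 percentage points higher from compound 2 to compound 3 (beyond the scatter) with the rest of the structure unchanged. Among these compounds, this is the first comparison that isolates a single place. No measured property bears on the size of this step.

On these data alone, whether amino depresses the number or methyl raises it remains open. So does how a methoxy group or a chlorine atom would read at this position.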